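Replacing the benzyl substituents on a shared core

This account rests on a few compounds, and the source may have more. Where it says the series, first, only, none or still open, it means among the compounds named here.

Among the compounds with values here, in a functional assay on CCRF-CEM cells (Homo sapiens) for antiproliferative activity, with a stated time of 72 h (a lower number here means a stronger inhibitor, a higher number a weaker inhibitor), two compounds built on the same core have numbers so far. Compound 1 (`OC[C@H]1O[C@@H](n2cnc3c(NCc4ccccc4Cl)ncnc32)[C@H](O)[C@@H]1O`) gives 14500 nM, and compound 2 (`OC[C@H]1O[C@@H](n2cnc3c(NCc4ccc(F)cc4Cl)ncnc32)[C@H](O)[C@@H]1O`) gives 20900 nM. These two values lie within the scatter of each other, so compound 2 stands level with compound 1 on the available data.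

Compound 3 (`Cc1ccc(O)c(CNc2ncnc3c2ncn3[C@@H]2O[C@H](CO)[C@@H](O)[C@H]2O)c1`) is unmeasured and differs from compound 2 in one group: 2-hydroxy-5-methylphenyl in place of 2-chloro-4-fluorophenyl on a saturated chain carbon bound to a nitrogen on an aromatic ring. In plain words, 2-hydroxy-5-methylphenyl sits in place of 2-chloro-4-fluorophenyl, on a saturated chain carbon bound to a nitrogen on an aromatic ring.

Within the data shown here, only one measured step bears on this change, the swap of fluoro for hydrogen, which is a 1.4-fold higher number from compound 1 to compound 2 (0.16 log units; within the scatter). Among the measured compounds shown here, that step is small, but it is a weak guide, since no measured compound carries a hydroxy or methyl group on this ring. No clear step beyond the scatter is therefore expected, although the uncertainty is wide. The expected step is a 1.5-fold lower number from compound 2 to compound 3 (0.17 log units; within the scatter).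

For compound 3 the estimated value is 14000 nM, with an expected range from 4000 nM to 50000 nM.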

Compound 3, half-maximal inhibitory concentration: 1900 nM
Compound 3: the middle estimate sits 7.4-fold (0.87 log units) above what was measured, outside the stated range (below it).
By their numbers in this assay, from the lowest: compound 3; then compounds 1 and 2 (each within the scatter of the next).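

In this assay the group on a saturated chain carbon bound to a nitrogen on an aromatic ring can clearly shift the number: 2-hydroxy-5-methylphenyl in place of 2-chloro-4-fluorophenyl gives an 11-fold lower number from compound 2 to compound 3 (1.04 log units; beyond the scatter) and in place of 2-chlorophenyl gives a 7.6-fold lower number from compound 1 to compound 3 (0.88 log units; beyond the scatter) on the same shared core. Within the data shown here, the only earlier step, a fluoro in place of a hydrogen, stayed within the scatter, so it gave no sign that this position could respond so strongly; compound 3 now sits beyond the scatter of both earlier compounds, on the side of stronger inhibition. No measurement shown here accounts for the size of this step.

This single change removes the chloro and fluoro groups and adds a hydroxy and a methyl group at once, so the compounds shown cannot say which of these differences carries the step. A phenyl ring carrying only the hydroxy group or only the methyl group would separate them, and a methoxy group or an amine in place of the hydroxy would show whether the lower number survives a change to that group.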